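This account rests on a few compounds, and the source may have more. Where it says the series, first, only, none or still open, it means among the compounds named here.

Compound 3 `C[C@@H](O)[C@H]1C(=O)N2C(C(=O)OCOC(=O)OC3CCCCC3)=C(S[C@@H]3CN[C@H](C(=O)Nc4cccc(C(=O)O)c4)C3)[C@H](C)[C@H]12` is the carbonate-type member of the set. In an ADME assay for metabolic stability, read by LC-MS, with a stated time of 3 h, at pH 6.5, tested at 50 uM (on this read-out higher numbers stand for a more stable compound and lower numbers for a less stable compound), compound 3 gives > 95%, which is a limit of the assay and not a number. Compound 1 `C[C@@H](O)[C@H]1C(=O)N2C(C(=O)OCOC(=O)C3CCCCC3)=C(S[C@@H]3CN[C@H](C(=O)Nc4cccc(C(=O)O)c4)C3)[C@H](C)[C@H]12` and compound 2 `CCOC(=O)C1=C(S[C@@H]2CN[C@H](C(=O)Nc3cccc(C(=O)O)c3)C2)[C@H](C)[C@@H]2[C@@H]([C@@H](C)O)C(=O)N12` differ from compound 3 only at the oxygen next to the carbonyl group. In this assay compound 1 gives > 95%, a limit. Compound 2 gives > 95%, also a limit. The steps a step that the two limits leave unreadable from compound 1 to compound 2, a step that the two limits leave unreadable from compound 1 to compound 3 and a step that the two limits leave unreadable from compound 2 to compound 3 are therefore unreadable, all three values sitting at the limit of > 95% in this assay, at which 3 of the 3 values shown sit. Compound 4 `CC(C)OC(=O)C1=C(S[C@@H]2CN[C@H](C(=O)Nc3cccc(C(=O)O)c3)C2)[C@H](C)[C@@H]2[C@@H]([C@@H](C)O)C(=O)N12` arises from compound 3 by isopropyl in place of ((cyclohexyloxycarbonyl)oxy)methyl on an oxygen next to a carbonyl group. Within the data shown here, no measured step gives a readable size for such a change, so no shift beyond the scatter is expected for a step that the limit leaves unreadable from compound 3 to compound 4. Compound 4 is accordingly estimated at 97%, with a range of 90% to 100%.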

Compound 4, percent of the compound remaining: > 95%
Compound 4: a limit, no number (the forecaster's own chance of this, stated with the estimate: 85%); the middle value is on the limit's open side.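

In this assay compound 4 gives > 95%, a limit and not a number. Its steps from compound 1, compound 2 and compound 3 cannot be read: the limit of > 95% in this assay, at which 4 of the 4 values shown sit.

The compounds shown leave open whether any group on this oxygen separates from another in this assay.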